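From an Anilide to an Aryl Ester on a Long Chain

The compounds below may be only part of what the source reports. "The series", "measured", "known", "first", "only" and "open" are said of these compounds alone.

Measured compounds:
Compound 1, `CCCOc1ccc(NC(=O)CSc2nnc(Cc3nn(C)c(=O)c4ccccc34)n2C)cc1`, in an assay on isolated protein (Mus musculus) for inhibition of IL15-IL15 receptor (Homo sapiens), read by resazurin assay, with stated times of 30 min and 2.5 days (a higher number here means a weaker inhibitor, a lower number a stronger inhibitor), gives > 30000 nM, which is a limit of the assay and not a number.
Compound 2, `CC(C)Oc1ccc(NC(=O)CSc2nnc(Cc3nn(C)c(=O)c4ccccc34)n2C)cc1`, gives > 30000 nM, also a limit.
Compound 3, `Cn1c(Cc2nn(C)c(=O)c3ccccc23)nnc1SCCCCCCCC(=O)Nc1ccc(I)cc1`, gives 1300 nM.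

Within the data shown here, compound 3 holds the only measured number here; the other two values sit at the limit of > 30000 nM in this assay, at which 2 of the 3 values shown sit. The step from compound 1 to compound 2, a step that the two limits leave unreadable from compound 1 to compound 2, has both ends at a limit and so cannot be read. Compound 4, `Cn1c(Cc2nn(C)c(=O)c3ccccc23)nnc1SCCCCCCCC(=O)Oc1ccc(Cl)cc1Cl`, differs from compound 3 by 2,4-dichlorophenoxy in place of (4-iodophenyl)amino on a carbonyl carbon. Among the measured compounds shown here, no measured step touches this change: the one recorded step concerns a different part of the molecule and is unreadable. There is thus no basis for expecting a move beyond the scatter in either direction. Compound 4 is estimated at 3000 nM, between 700 nM and 30000 nM, an expected step of a 2.3-fold higher number from compound 3 to compound 4 (0.36 log units; beyond the scatter).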

Compound 4, half-maximal inhibitory concentration: 800 nM
Beside the measured number, compound 4's estimate is 3.8-fold (0.57 log units) above it, and the stated range covers the measured number.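

In this assay, the swap gives a 1.6-fold lower number from compound 3 to compound 4 (0.21 log units; within the scatter), so on this carbonyl carbon an aryl ester without the amide hydrogen can stand in for the anilide with no move beyond the scatter. Among these compounds, this is the first step that can be read, as the earlier step has a limit at both ends. Nothing measured here explains the result.

Still open, going by these compounds, is how (2,4-dichlorophenyl)amino would read on this carbonyl carbon, which would separate the linking atom from the ring's halogens. On these data alone, a longer chain carrying the ester is also open.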